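A few compounds are considered here, and "the series" means these few. Any claim that something is new, unique, unknown or untested is made for them only; others in the source may bear on it.

Compound 2 `CCOC(=O)C1=C(Nc2ccc([N+](=O)[O-])cc2)S/C(=C\c2ccc[nH]2)C1=O` and compound 1 `CCOC(=O)C1=C(Nc2ccccc2)S/C(=C\c2ccc[nH]2)C1=O` have both been tested in a functional assay on JAR cells (Homo sapiens) for inhibition, read by MTT assay, with a stated time of 72 h, tested at 10 uM; on this read-out lower numbers stand for less inhibition and higher numbers for more inhibition at the one concentration tested (going by the name of the read-out). Compound 2 gives 54.9%, while compound 1 gives 49.2%; the step of a number 5.7 percentage points higher from compound 1 to compound 2 (within the scatter) lies within the scatter. Compound 3 `CCOC(=O)C1=C(Nc2ccc(CC)cc2)S/C(=C\c2ccc[nH]2)C1=O` differs from compound 2 by ethyl in place of nitro on an aromatic carbon. Within the data shown here, the only measured step touching this position, a number 5.7 percentage points higher from compound 1 to compound 2 (within the scatter), was within the scatter, so nothing beyond the scatter is expected for compound 3 in this assay. For compound 3 the expected step is a number 4.9 percentage points lower from compound 2 to compound 3 (within the scatter). Compound 3 is estimated at 50%, with a range from 35% to 65%.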

Compound 3, a percentage reported as inhibition, at one concentration (the size of the read-out at that concentration, not a potency): < 10%
Compound 3 ended at the assay's limit; the forecaster's own chance of this, stated with the estimate: 0%; middle value at least 40 percentage points from the limit.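

At this position on the aromatic ring, the earlier pair had shown no difference beyond the scatter, but the position is clearly not indifferent in this assay. Ethyl in place of nitro gives a number at least 44.9 percentage points lower from compound 2 to compound 3 (beyond the scatter), and ethyl in place of hydrogen gives a number at least 39.2 percentage points lower from compound 1 to compound 3 (beyond the scatter), so ethyl stands apart from both earlier groups. The value of compound 3 is a limit of the assay and not a number: the limit of < 10% in this assay, at which 1 of the 3 values shown sits.

On these data alone, it remains open whether this loss is particular to ethyl or also extends to methyl, a longer chain, an amine or a carboxylic acid at this place.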